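The source may hold more compounds than are shown below. What is called first, only, known or untested is meant among the compounds shown, and "the series" means these compounds.

Working notes on the series. In an ADME assay on ECV-304 cells (Homo sapiens) for cytotoxicity, read by MTT assay, with a stated time of 72 h (a lower number here means a stronger inhibitor, a higher number a weaker inhibitor), compound 1 (`COc1ccc(C2=C(c3cc(OC)c(OC)c(OC)c3)C(=O)C(OC(C)=O)C2)cc1OC(C)C`) gives > 100 ug/mL as a limit of the assay, not a number. Compound 2 (`COc1ccc(C2=C(c3cc(OC)c(OC)c(OC)c3)CC(O)C2=O)cc1[N+](=O)[O-]`) gives > 100 ug/mL as a limit too. For the measured compounds named here, the series so far offers only the limit of > 100 ug/mL in this assay, at which 2 of the 2 values shown sit, and no numerical value, and no measured step gauges the change to come. Compound 3 (`COc1ccc(C2=C(c3cc(OC)c(OC)c(OC)c3)C(=O)C(OC(C)=O)C2)cc1F`) keeps the core of compound 1 and carries fluoro in place of isopropoxy on an aromatic carbon, ortho to a methoxy group (fluoro in place of isopropoxy on an aromatic carbon) with the rest unchanged. In this assay a small move toward a stronger inhibitor is expected, though a further limit remains the likeliest single outcome. The expected step is an at least 1.2-fold lower number from compound 1 to compound 3 (0.09 log units; that floor lies within the scatter) on this estimate. Compound 3 is estimated at 80 ug/mL with a range of 25 ug/mL to 100 ug/mL for the coming measurement.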

Compound 3, half-maximal inhibitory concentration: 41 ug/mL
Compound 3: the middle estimate sits 2.0-fold (0.29 log units) above what was measured; measured number inside the range.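

In this assay, fluoro in place of isopropoxy on an aromatic carbon, ortho to a methoxy group, gives an at least 2.4-fold lower number from compound 1 to compound 3 (0.38 log units; beyond the scatter). This single change, with the rest of the structure the same, is enough to bring a compound of this series to a numerical value. The step is stated only as a minimum, and compound 3 is the one compound shown that gives a number rather than a limit: the limit of > 100 ug/mL in this assay, at which 2 of the 3 values shown sit.

As far as these compounds go, whether the step comes from losing the isopropoxy or from gaining the fluoro stays open, and a hydrogen, a chloro or an amine at this position would separate the two. Compound 2 differs from compound 3 in more than one place, so that pair gives no reading of this change.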